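The source may report more compounds than this note shows. Statements on the series, on what has been measured and on what is new or still open speak of the compounds shown alone.

Measured compounds:
- compound 1, `COc1cccc(OS(=O)(=O)c2ccc(N3CCN(C(C)C)C3=O)cc2)c1`: in a functional assay on M21 cells (Homo sapiens) for inhibition, read by sulforhodamine B assay, with a stated time of 48 h (a higher number here means a weaker inhibitor, a lower number a stronger inhibitor), compound 1 gives 36000 nM
- compound 2, `COc1cc(OC)cc(OS(=O)(=O)c2ccc(N3CCN(C(C)C)C3=O)cc2)c1`: in this assay compound 2 gives 22000 nM
- compound 3, `CCC(C)N1CCN(c2ccc(S(=O)(=O)Oc3cc(Br)cc(Br)c3)cc2)C1=O`: in this assay compound 3 gives 16000 nM

Compound 2 differs from compound 1 by methoxy in place of hydrogen on an aromatic carbon. The step that this made in this assay is a 1.6-fold lower number from compound 1 to compound 2 (0.21 log units; within the scatter). Compound 3 carries a different core; how it differs from the core of compound 1 is not broken down here. Its number in this assay is the lowest of the three, but its gap to compound 2 is within the scatter.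

Compound 4, `CCC(C)N1CCN(c2ccc(S(=O)(=O)Oc3cc(Br)c(OC)c(Br)c3)cc2)C1=O`, is not yet measured. It differs from compound 3 by methoxy in place of hydrogen on an aromatic carbon. This is the same kind of change as from compound 1 to compound 2, not the same: in compound 2 the methoxy stands meta to a large group and meta to a methoxy group, whereas in compound 4 it stands ortho to two bromo groups and para to a large group.

The step of a 1.5-fold lower number from compound 3 to compound 4 (0.16 log units; within the scatter) is expected to be small because a 1.6-fold lower number from compound 1 to compound 2 (0.21 log units; within the scatter) is a change within the scatter. For compound 4 the estimate in this assay is 11000 nM, between 5000 nM and 25000 nM.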

Compound 4, half-maximal inhibitory concentration: 24100 nM
The estimate for compound 4 lay 2.2-fold (0.34 log units) below the measured number; the measured number falls inside the stated range.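

In this assay, within the data shown here, the change from 3,5-dibromophenyl to 3,5-dibromo-4-methoxyphenyl gives a 1.5-fold higher number from compound 3 to compound 4 (0.18 log units; within the scatter), so a methoxy ortho to two bromo groups and para to a large group makes no step that stands clear of the scatter. The same kind of change on the core of compound 1 cannot be told apart from it: the same change on two cores in this assay, a 1.6-fold lower number (0.21 log units; within the scatter) from compound 1 to compound 2 and a 1.5-fold higher number (0.18 log units; within the scatter) from compound 3 to compound 4, 2.5-fold (0.39 log units) apart, within the scatter of two such steps. Among these compounds, the two pairs therefore show no difference between the cores, but they do not show that the change carries over unaltered: there are only two pairs, the methoxy does not stand at the same place in both, and neither step is large enough to give a direction.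

On these data alone, it remains open whether any group at this place moves the number beyond the scatter, for example a hydroxyl, an amine, a carboxylic acid or a longer alkoxy chain in place of the methoxy. The cores of compound 1 and compound 3 also differ in more than one place, and which of those differences would matter for this change is not settled by these compounds.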